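The source may report more compounds than this note shows. Statements on the series, on what has been measured and on what is new or still open speak of the compounds shown alone.

Measured compounds: compound 1 `CCCCCCCCn1cc(COC2(C(F)(F)F)Oc3ccccc3C=C2C(=O)OCC)nn1` with > 150000 nM; compound 2 `CCOC(=O)C1=Cc2ccccc2OC1(OCc1cc(-c2ccc3ccccc3c2)no1)C(F)(F)F` with > 150000 nM; compound 3 `CCOC(=O)C1=Cc2ccccc2OC1(OCc1cc(-c2ccc(Cl)cc2)no1)C(F)(F)F` with 19100 nM.

In a functional assay on A549 cells (Homo sapiens) for inhibition, read by MTT assay, with a stated time of 24 h (a higher number here means a weaker inhibitor, a lower number a stronger inhibitor), compound 1 reaches only a limit of the assay, and so its standing among the three cannot be placed more closely than that; two of the three values shown share that limit (the limit of > 150000 nM in this assay, at which 2 of the 3 values shown sit). Compound 4 `CCOC(=O)C1=Cc2ccccc2OC1(OCc1cn(-c2ccc(C)cc2)nn1)C(F)(F)F` differs from compound 1 by 4-methylphenyl in place of octyl on an aromatic nitrogen. Among the measured compounds shown here, the only step that bears on it is an at least 7.8-fold lower number from compound 2 to compound 3 (0.89 log units; beyond the scatter), where a smaller aryl group on a different five-membered ring gave a clearly lower number. By loose analogy a modest step downward is expected in this assay, so compound 4 is estimated at 80000 nM (range 15000 nM to 300000 nM), which would mean an expected change of an at least 1.8-fold lower number from compound 1 to compound 4 (0.27 log units; that floor lies within the scatter).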

Compound 4, half-maximal inhibitory concentration: 19700 nM
Compound 4: the middle estimate sits 4.1-fold (0.61 log units) above what was measured, within the range that was stated.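

In this assay, the substituent on the aromatic nitrogen of the five-membered ring now proves to matter: 4-methylphenyl in place of octyl gives an at least 7.6-fold lower number from compound 1 to compound 4 (0.88 log units; beyond the scatter). A six-membered aromatic ring of carbon only thus takes the place of a chain with no ring, and the number falls beyond the scatter. Compound 1 stands at a limit of the assay, so the step gives only a floor: the limit of > 150000 nM in this assay, at which 2 of the 4 values shown sit.

The compounds shown leave open whether a butyl chain on that nitrogen would also bring the number down. They also leave open how an amine or a carboxylic acid on the phenyl ring in place of the methyl would read.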